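The source may report more compounds than this note shows. Statements on the series, on what has been measured and on what is new or still open speak of the compounds shown alone.

Working notes on the series. Compound 1 `Oc1ccc(-c2cc(-c3cccs3)cc(-c3cccc(O)c3)n2)cc1` gives 85.7% in an assay on isolated protein for inhibition of DNA topoisomerase 1 (Homo sapiens), with a stated time of 30 min, tested at 100 uM; on this read-out lower numbers stand for a weaker effect and higher numbers for a stronger effect at the one concentration tested. Within the data shown here, compound 2 `Oc1cccc(-c2cc(-c3cccnc3)cc(-c3ccccc3O)n2)c1` gives 1.9% in this assay, which is the lowest of the two numbers so far; the nearest number is that of compound 1, and the gap between them lies beyond the scatter. The two compounds differ in more than one place, so nothing is counted between them and their values are simply set side by side.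

Compound 3 `Oc1ccc(-c2cc(-c3cccnc3)cc(-c3cccc(O)c3)n2)cc1` has not yet been measured in this assay. It is reached from compound 2 by one change: 4-hydroxyphenyl in place of 2-hydroxyphenyl on an aromatic carbon. After this change compound 3 shares the 4-hydroxyphenyl and 3-hydroxyphenyl groups with compound 1 and the pyridin-3-yl group with compound 2; which of the groups carries the gap between compound 1 and compound 2 cannot be told from the two values alone. The step from compound 2 to compound 3 is therefore expected to run upward, of uncertain size, as a number 38.1 percentage points higher from compound 2 to compound 3 (beyond the scatter). Compound 3 is estimated at 40% in this assay, within a range from 5% to 85%.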

Compound 3, a percentage reported as inhibition, at one concentration (the size of the read-out at that concentration, not a potency): 5.9%
Estimate against measurement, compound 3: 34.1 percentage points above, and the stated range covers the measured number.
By their numbers in this assay, from the lowest: compounds 2 and 3 (each within the scatter of the next); then compound 1.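

In this assay the exchange of 2-hydroxyphenyl for 4-hydroxyphenyl on the aromatic carbon next to the ring nitrogen gives a number 4 percentage points higher from compound 2 to compound 3 (within the scatter) and so, with pyridin-3-yl on the core, the read-out does not separate these two hydroxyphenyl groups at this position. Among these compounds, the other single exchange, pyridin-3-yl in place of thiophen-2-yl on an aromatic carbon, gives a number 79.8 percentage points lower from compound 1 to compound 3 (beyond the scatter) and is the first step to show that one group change alone can take the read-out from high to close to nothing, with both hydroxyphenyl groups of compound 1 kept in place. Nothing at hand bears on the reason for either step, so both stand only as observed differences at the one concentration tested.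

The compounds shown leave open whether 2-hydroxyphenyl and 4-hydroxyphenyl would also read alike with thiophen-2-yl on the core, since the step between them is known only with pyridin-3-yl present. Also open, as far as these compounds go, is how the read-out responds to other groups at the thiophen-2-yl place, such as an unsubstituted phenyl or furan-2-yl, or to an amine or a carboxylic acid in place of the hydroxyl on either hydroxyphenyl group.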